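The compounds below may be only part of what the source reports. "The series", "measured", "known", "first", "only" and "open" are said of these compounds alone.

In an ADME assay on MCF7-DOX cells (Homo sapiens) for cytotoxicity, read by MTT assay, with a stated time of 48 h (a lower number here means a stronger inhibitor, a higher number a weaker inhibitor), compound 1 (`COc1cc(O)c(C(=O)/C=C/c2cccc(N3CCNCC3)c2)c(OC)c1`) gives (99200 nM) and compound 2 (`COc1cc(O)c(C(=O)/C=C/c2cccc(N3CCN(C)CC3)c2)c(OC)c1`) gives (62200 nM). These two differ only on an amine nitrogen in a ring, and the step between them (a 1.6-fold lower number from compound 1 to compound 2 (0.20 log units; within the scatter)) is small. Compound 3 (`COc1cc(OC)c(C(=O)/C=C/c2cccc(N3CCN(C(=O)OC(C)(C)C)CC3)c2)c(O)c1CC=C(C)C`) gives (42600 nM), a number within the scatter of compound 2 and clearly under that of compound 1.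

Compound 4 (`COc1cc(O)c(C(=O)/C=C/c2cccc(N3CCN(C(=O)OC(C)(C)C)CC3)c2)c(OC)c1`) is compound 3 with a single change (hydrogen in place of 3-methylbut-2-en-1-yl on an aromatic carbon): hydrogen in place of 3-methylbut-2-en-1-yl on an aromatic carbon. Within the data shown here, no measured step covers this change, and the one step available concerns a different place on the molecule. Among the measured compounds shown here, the only other guide is that compound 1 (99200 nM) and compound 2 (62200 nM) also carry hydrogen at that carbon, though they differ from compound 4 on the ring nitrogen. A small rise in the number, probably within the scatter, is therefore expected, and the estimated step is (a 1.4-fold higher number from compound 3 to compound 4 (0.15 log units; within the scatter)). For compound 4 the expected value is (60000 nM), with an estimated range from (30000 nM) to (120000 nM).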

Compound 4, half-maximal inhibitory concentration: 56700 nM
Compound 4: middle estimate off by 1.1-fold (0.02 log units), on the high side; low and high end bracket the measured number.
By their numbers in this assay, from the lowest: compounds 3, 4, 2 and 1 (each within the scatter of the next, the first and the last beyond it).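

In this assay, replacing the 3-methylbut-2-en-1-yl on this aromatic carbon with hydrogen gives a step that stays within the scatter (a 1.3-fold higher number from compound 3 to compound 4 (0.12 log units; within the scatter)), so the whole chain can go from this position without a change that can be told from repeat noise. Compound 4 also shows that tert-butoxycarbonyl on the ring nitrogen cannot be told apart from methyl (a 1.1-fold lower number from compound 2 to compound 4 (0.04 log units; within the scatter)) or from hydrogen (a 1.7-fold lower number from compound 1 to compound 4 (0.24 log units; within the scatter)), as both steps also lie within the scatter. No measurement shown here bears on the reason for these results.

Among these compounds, only one pair of compounds speaks for this carbon, so it remains open whether an amine or a longer chain there would shift the number beyond the scatter. From the compounds shown here alone, the effect of an acetyl group on the ring nitrogen also remains open.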